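Replacing a Large Ring Group with Methyl

The source may report more compounds than this note shows. Statements on the series, on what has been measured and on what is new or still open speak of the compounds shown alone.

Compound 1 `CCCCc1nc(=O)c(S(=O)(=O)c2ccc(-c3cccnc3)cc2)c(O)n1-c1c(OC)cccc1OC`: 3%
Compound 2 `CCCCc1nc(=O)c(S(=O)(=O)c2ccc(-n3cc(Cl)ccc3=O)cc2)c(O)n1-c1c(OC)cccc1OC`: 74%

Among the compounds with values here, in an ADME assay on microsomes from liver (Rattus norvegicus) for metabolic stability, using NADPH, with a stated time of 10 min (a higher number here means that more of the compound is left, a lower number that less of the compound is left), compound 2 gives 74%, the higher of the two numbers measured so far, while compound 1 gives 3%. Compound 3 `CCCCc1nc(=O)c(S(=O)(=O)c2ccc(C)cc2)c(O)n1-c1c(OC)cccc1OC` carries one carbon atom in place of a group of 8 heavy atoms (5 carbon, 1 nitrogen, 1 oxygen, 1 chlorine; one six-membered aromatic ring with 1 hetero atom), on an aromatic carbon. Within the data shown here, only one measured step touches this position: a number 71 percentage points higher from compound 1 to compound 2 (beyond the scatter). That step shows the group at this place matters greatly in this assay, yet methyl matches neither earlier group, so the direction is uncertain. A fall is nevertheless expected, roughly a number 44 percentage points lower from compound 2 to compound 3 (beyond the scatter). Compound 3 is expected to give 30%, with a range from 3% to 75%.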

Compound 3, percent of the compound remaining: 74%
The estimate for compound 3 lay 44 percentage points below the measured number; low and high end bracket the measured number.
By their numbers in this assay, from the lowest: compound 1; then compounds 2 and 3 (each within the scatter of the next).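

In this assay, methyl in place of the large ring group gives no change at the digits printed from compound 2 to compound 3 (within the scatter) and methyl in place of pyridin-3-yl gives a number 71 percentage points higher from compound 1 to compound 3 (beyond the scatter). So a large ring group is not needed at this place for a high number, and among these three groups only the pyridin-3-yl of compound 1 goes with a low one. Nothing measured here explains this difference. Still open, on these data alone, is whether a plain phenyl ring would behave like pyridin-3-yl. Also open, as far as these compounds go, is whether an amine or a carboxylic acid at this place would match methyl.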